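Removing the Fluoro Group: An Expected Cytotoxicity Reading

This account rests on a few compounds, and the source may have more. Where it says the series, first, only, none or still open, it means among the compounds named here.

Compounds measured so far:
Compound 1 `COc1nc2ccc(Br)cc2cc1C(c1ccccc1)n1cc(-c2ccc(Br)cc2)nn1` gives 6.92%
Compound 2 `COc1nc2ccc(Br)cc2cc1C(c1ccccc1)n1cc(-c2ccc(F)cc2)nn1` gives 4.27%

Both compounds share one core and differ only in the halogen on the outer six-membered ring. In an ADME assay on HeLa cells (Homo sapiens) for cytotoxicity, read by sulforhodamine B assay, with a stated time of 48 h, tested at 10 uM (a lower number here means less inhibition, a higher number more inhibition at the concentration tested (going by the name of the read-out)), compound 1 gives 6.92%, while compound 2 gives 4.27%. Going by the values given here, the only step between them, a number 2.7 percentage points lower from compound 1 to compound 2 (within the scatter), falls within the usual scatter, so the two readings cannot be told apart: both compounds sit at the low end of the scale, barely inhibiting the cells at the concentration tested.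

The next compound, compound 3 `COc1nc2ccc(Br)cc2cc1C(c1ccccc1)n1cc(-c2ccccc2)nn1`, takes the change one stage further: hydrogen in place of fluoro on an aromatic carbon. Among the compounds with values here, the single step already seen exchanged one halogen for another at the same place and moved the reading by a number 2.7 percentage points lower from compound 1 to compound 2 (within the scatter), a shift inside the scatter. Taking away the fluoro altogether is a comparable, small change, and nothing among the measured compounds suggests the reading should move beyond the scatter. Compound 3 is therefore expected to give 5%, with a plausible range from -5% to 15%, meaning an estimated step of a number 0.7 percentage points higher from compound 2 to compound 3 (within the scatter).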

Compound 3, a percentage reported as inhibition, at one concentration (the size of the read-out at that concentration, not a potency): 13.9%
The estimate for compound 3 lay 8.9 percentage points below the measured number; the measured number falls inside the stated range.
By their numbers in this assay, from the lowest: compounds 2, 1 and 3 (each within the scatter of the next).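

At this place on the outer ring, para to a large group, three substituents can now be compared in this assay, and removing the halogen altogether gives a number 9.6 percentage points higher from compound 2 to compound 3 (within the scatter). Hydrogen in place of bromo likewise gives a number 7 percentage points higher from compound 1 to compound 3 (within the scatter), so neither step leaves the scatter, and hydrogen, fluoro and bromo cannot be told apart here, even though the 4-fluorophenyl to phenyl change gives the largest step seen so far in this small series. Nothing available explains these readings.

The compounds shown carry only hydrogen, fluoro or bromo at this place, so it remains open whether a quite different group there, such as an amine or a carboxylic acid, would move the reading beyond the scatter. As far as these compounds go, it is also open whether changes elsewhere on the shared core, for instance at the methoxy group or the unsubstituted phenyl ring, would give clearer differences in this assay than this halogen swap has.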